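Aryl-sulfonyl piperazine series: rat exposure notes

This account rests on a few compounds, and the source may have more. Where it says the series, first, only, none or still open, it means among the compounds named here.

Measured compounds in an ADME assay on the whole organism (plasma) for pharmacokinetics, with Rattus norvegicus as the target, with a stated time of 6 h, at a dose of 10 mg/kg by the oral route; on this read-out lower numbers stand for lower exposure and higher numbers for higher exposure at the dose given:
- compound 1 `O=c1c(OC2CCCC2)c(N2CCN(S(=O)(=O)Cc3cccc(O)c3)CC2)cnn1-c1cc(F)cc(F)c1`: compound 1 gives "below limit of detection" (no number reported).
- compound 2 `CC1(COc2c(N3CCN(S(=O)(=O)Cc4ccc(N)cc4)CC3)cnn(-c3cccc(Cl)c3)c2=O)CC1`: compound 2 gives 8100 ng.h/mL.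
- compound 3 `COc1cc(CS(=O)(=O)N2CCN(c3cnn(-c4cccc(Cl)c4)c(=O)c3OCC3(C)CC3)CC2)ccc1N`: compound 3 gives 13100 ng.h/mL.

The entry of compound 1 is a limit of the assay, not a number. Among the two numbers, compound 2 has the lower one, and its nearest neighbour is compound 3, with a 1.6-fold higher number from compound 2 to compound 3 (0.21 log units; within the scatter) separating them; the two therefore cannot be told apart.

Compound 4 `CC(C)c1cc(CS(=O)(=O)N2CCN(c3cnn(-c4cccc(Cl)c4)c(=O)c3OCC3(C)CC3)CC2)ccc1N` is not yet measured. It differs from compound 2 in one place: isopropyl in place of hydrogen on an aromatic carbon.

Within the data shown here, the only measured step that speaks to this change is the one from compound 2 to compound 3, where methoxy replaces hydrogen on the same aromatic carbon of the 4-aminophenyl ring, ortho to the amino group. That step, a 1.6-fold higher number from compound 2 to compound 3 (0.21 log units; within the scatter), stayed within the scatter. On that single precedent, a substituent entering at this carbon is not expected to shift exposure beyond the scatter, though one step is thin ground and the entering group is carbon-only rather than oxygen-bearing.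

Compound 4 is therefore expected to land near compound 2, with an estimated 8000 ng.h/mL (range 3500 ng.h/mL to 18000 ng.h/mL), meaning an expected step of a 1.0-fold lower number from compound 2 to compound 4 (0.01 log units; within the scatter).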

Compound 4, area under the concentration-time curve: 2100 ng.h/mL
Compound 4: the middle estimate sits 3.8-fold (0.58 log units) above what was measured; measured number below the stated range.
By their numbers in this assay, from the lowest: compound 4; then compounds 2 and 3 (each within the scatter of the next).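

In this assay, the aromatic carbon ortho to an amino group is not indifferent to what enters there: isopropyl in place of hydrogen gives a 3.9-fold lower number from compound 2 to compound 4 (0.59 log units; beyond the scatter), whereas methoxy in place of hydrogen gave only a 1.6-fold higher number from compound 2 to compound 3 (0.21 log units; within the scatter). The exchange of methoxy for isopropyl on this same carbon gives a 6.2-fold lower number from compound 3 to compound 4 (0.80 log units; beyond the scatter), so the outcome depends on the identity of the entering group and not merely on this carbon carrying a substituent. No accompanying measurement bears on the origin of this lower exposure, and the result remains an observation without an explanation.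

The compounds shown leave open whether a methyl, an ethyl or a fluorine at this carbon would track compound 3 or compound 4, and thus whether the lower number belongs to isopropyl alone or extends to other groups. Each step also rests on a single pair on the shared core of compound 2, so how far the isopropyl effect carries to other members of the series cannot be told.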